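The source may report more compounds than this note shows. Statements on the series, on what has been measured and on what is new or still open speak of the compounds shown alone.

Measured so far in a functional assay on A549 cells (Homo sapiens) for cytotoxicity, read by sulforhodamine B assay; on this read-out lower numbers stand for stronger inhibition and higher numbers for weaker inhibition:
compound 1 `C=C1[C@@H](C/C=C2/C(=O)OC[C@H]2OC(C)=O)[C@]2(C)CC[C@@H](OC(C)=O)[C@@](C)(CO[Si](C)(C)C(C)(C)C)[C@H]2C[C@@H]1O`, 6850 nM
compound 2 `C=C1[C@@H](OC(C)=O)C[C@@H]2[C@](C)(CO[Si](C)(C)C(C)(C)C)[C@H](OC(C)=O)CC[C@@]2(C)[C@@H]1C[C@@H](Nc1cccc(F)c1)C1=CCOC1=O`, 4060 nM
compound 3 `C=C1[C@@H](OC(C)=O)C[C@@H]2[C@](C)(COC=O)[C@H](OC(C)=O)CC[C@@]2(C)[C@@H]1C[C@@H](Nc1cccc(F)c1)C1=CCOC1=O`, 23200 nM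

Compound 2 carries the lowest number of the three. Compound 1 sits within the usual scatter of it, whereas compound 3 lies beyond it: a 5.7-fold higher number from compound 2 to compound 3 (0.76 log units; beyond the scatter), a change on the oxygen on a saturated carbon. Compound 4 `C=C1[C@@H](OC(C)=O)C[C@@H]2[C@](C)(CO[Si](C)(C)C(C)(C)C)[C@H](OC(C)=O)CC[C@@]2(C)[C@@H]1C[C@@H](Nc1ccc(OC)c(OC)c1)C1=CCOC1=O` keeps everything of compound 2 apart from the substituent on the amine nitrogen: 3,4-dimethoxyphenyl in place of 3-fluorophenyl on an amine nitrogen. Going by the values given here, no measured step touches this part of the molecule; the one measured step alters a different place, so nothing bears directly on the change to compound 4. The expectation is therefore a step of a 1.0-fold lower number from compound 2 to compound 4 (0.01 log units; within the scatter) in this assay, with no direction beyond the scatter. Compound 4 is estimated at 4000 nM, range 1500 nM to 11000 nM.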

Compound 4, half-maximal inhibitory concentration: 4870 nM
Compound 4: the middle estimate sits 1.2-fold (0.09 log units) below what was measured; measured number inside the range.
By their numbers in this assay, from the lowest: compounds 2, 4 and 1 (each within the scatter of the next); then compound 3.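

In this assay, going by these compounds alone, the substituent on the amine nitrogen can be read for the first time: 3,4-dimethoxyphenyl in place of 3-fluorophenyl gives a 1.2-fold higher number from compound 2 to compound 4 (0.08 log units; within the scatter). Two aryl groups with different substituents therefore give values within the scatter of each other on the shared core. Within the data shown here, the only step beyond the scatter remains the change on the oxygen on a saturated carbon, a 5.7-fold higher number from compound 2 to compound 3 (0.76 log units; beyond the scatter). No measurement available here accounts for either step.

Open, as far as these compounds go, is whether a non-aromatic group on this nitrogen, such as cyclohexyl or benzyl, would give a step beyond the scatter. Also open, from the compounds shown here alone, is whether a carboxylic acid or a hydroxyl on the aromatic ring would do so.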